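Masking the Diol of Compound 2 as a Dioxolane

The compounds below may be only part of what the source reports. "The series", "measured", "known", "first", "only" and "open" are said of these compounds alone.

Compound 2 `O=C1c2c[n+]([O-])c3ccccc3c2C(=O)c2c1c1ccccc1n2Cc1cn(C[C@@H](O)CO)nn1` carries a 1-(2,3-dihydroxypropyl)-1H-1,2,3-triazol-4-yl group on a saturated chain carbon bound to an aromatic nitrogen. In a functional assay on MCF7 cells (Homo sapiens) for cytotoxicity, read by MTT assay, with a stated time of 72 h (a lower number here means a stronger inhibitor, a higher number a weaker inhibitor), compound 2 gives 600 nM, the lowest number among the three measured compounds. Compound 1 `CN1CCN(CCCCCn2c3c(c4ccccc42)C(=O)c2c[n+]([O-])c4ccccc4c2C3=O)CC1` gives 1260 nM, and compound 3 `O=C1c2c[n+]([O-])c3ccccc3c2C(=O)c2c1c1ccccc1n2CCCCN1CCNCC1` gives 12000 nM. The step of a 2.1-fold lower number from compound 1 to compound 2 (0.32 log units; beyond the scatter) and the step of a 20-fold higher number from compound 2 to compound 3 (1.30 log units; beyond the scatter) each exchange the whole group on that carbon, while the step of a 9.5-fold higher number from compound 1 to compound 3 (0.98 log units; beyond the scatter) alters the chain further out.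

Compound 4 `CC1(C)OC[C@H](Cn2cc(Cn3c4c(c5ccccc53)C(=O)c3c[n+]([O-])c5ccccc5c3C4=O)nn2)O1` differs from compound 2 in a smaller way: 2,2-dimethyl-1,3-dioxolan-4-yl in place of 1,2-dihydroxyethyl on a saturated chain carbon bound to an aromatic nitrogen. Going by the values given here, no measured step exchanges only a diol for its dioxolane, so the three steps bear on it loosely: they show that the group on this carbon can move the number by a modest to large amount, yet each alters far more than the terminus. Compound 4 is therefore expected near compound 2, at an estimated 1000 nM within a range from 400 nM to 3000 nM. The expected step is a 1.7-fold higher number from compound 2 to compound 4 (0.22 log units; within the scatter).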

Compound 4, half-maximal inhibitory concentration: 530 nM
Estimate against measurement, compound 4: 1.9-fold (0.28 log units) above; low and high end bracket the measured number.
By their numbers in this assay, from the lowest: compounds 4 and 2 (each within the scatter of the next); then compound 1; then compound 3.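

In this assay, going by these compounds alone, exchanging 1,2-dihydroxyethyl for 2,2-dimethyl-1,3-dioxolan-4-yl gives a 1.1-fold lower number from compound 2 to compound 4 (0.05 log units; within the scatter) and is the only step so far confined to the terminus of this group. The earlier steps shown here each exchanged far more, whereas this one shows that the terminus can lose its hydrogen-bond donors and gain a five-membered non-aromatic ring with no change beyond the scatter. Nothing measured here explains why the two termini give such similar numbers.

The compounds shown leave open what a single hydroxyl, a methyl ether or a primary amine would give at this terminus, and whether a carboxylic acid or a longer chain would be tolerated in the same way. They also leave open whether the opposite configuration at the defined stereocentre would read the same.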